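Notes on adding a second chloro group

The compounds below may be only part of what the source reports. "The series", "measured", "known", "first", "only" and "open" are said of these compounds alone.

compound 1 `NC(=S)N/N=C(\COc1ccc(F)cc1)c1ccc(Br)cc1`: 52300 nM
compound 2 `NC(=S)N/N=C(\COc1ccccc1Cl)c1ccc(Br)cc1`: 25100 nM

In an ADME assay on L929 cells (Mus musculus) for cytotoxicity, read by resazurin assay, with a stated time of 96 h (on this read-out lower numbers stand for higher toxicity in this test and higher numbers for lower toxicity in this test), compound 2 has the lower number of the two at 25100 nM, and compound 1 stands higher at 52300 nM. The next step leads to compound 3 `NC(=S)N/N=C(\COc1cccc(Cl)c1Cl)c1ccc(Br)cc1` and is chloro in place of hydrogen on an aromatic carbon, ortho to a chloro group.

For the measured compounds named here, only one measured step bears on this change, and it is a modest one: a 2.1-fold lower number from compound 1 to compound 2 (0.32 log units; beyond the scatter). That step exchanges one substituted phenyl group for another and does not add a group to the same ring. Going by the values given here, it is therefore only a loose guide, and no measured step shows the addition of a second chloro group. A step of similar modest size towards a lower number in this assay is expected, though one within the scatter would not be surprising. The expected change is a 1.5-fold lower number from compound 2 to compound 3 (0.17 log units; within the scatter). For compound 3 the estimated value is 17000 nM, with an expected range of 8000 nM to 35000 nM.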

Compound 3, half-maximal cytotoxic concentration: 23100 nM
Compound 3: middle estimate off by 1.4-fold (0.13 log units), on the low side; measured number inside the range.
By their numbers in this assay, from the lowest: compounds 3 and 2 (each within the scatter of the next); then compound 1.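

In this assay, chloro in place of hydrogen on an aromatic carbon, ortho to a chloro group and meta to a large group, gives a 1.1-fold lower number from compound 2 to compound 3 (0.04 log units; within the scatter). For the compounds shown here, this is the first step that adds a group to a ring already carrying a chloro group, something the earlier exchange of one substituted phenyl group for another, a 2.1-fold lower number from compound 1 to compound 2 (0.32 log units; beyond the scatter), could not show; at this position, the second chloro group gives no step beyond the scatter. Nothing measured here bears on the reason for this result.

From the compounds shown here alone, whether a different group at this position, such as a methoxy group, an amine or a carboxylic acid, would also stay within the scatter remains open, as does the reading for a chloro group here on a ring without the first chloro group. This single step also leaves open the other aromatic carbons of this ring and whether the same change would read alike on the core of compound 1 in this assay.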